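This account rests on a few compounds, and the source may have more. Where it says the series, first, only, none or still open, it means among the compounds named here.

In an ADME assay (Rattus norvegicus) for inhibition (a lower number here means a stronger inhibitor, a higher number a weaker inhibitor), the three measured compounds share one core and give numbers close to one another. Compound 1 `Cc1nc2c([nH]1)C(=O)C(Nc1ccc(OC(F)(F)F)cc1)=C(Cl)C2=O` gives 3000 nM. Compound 2 `Cc1nc2c(nc1C)C(=O)C(Nc1ccc(F)cc1)=CC2=O` gives 3100 nM; 3090 nM (2 entries), and the several entries of compound 2 in this assay, 3100 nM; 3090 nM (2 entries) agree closely. Compound 3 `Cc1nc2c(nc1C)C(=O)C(Nc1ccc(Cl)cc1)=CC2=O` gives 3300 nM; its distance from compound 1 lies within the usual scatter, so the two cannot be told apart on these numbers, and the entries of compound 2 sit equally close.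

Compound 4 `CCOc1ccc(NC2=CC(=O)c3nc(C)c(C)nc3C2=O)cc1` is not yet measured. It differs from compound 3 by ethoxy in place of chloro on an aromatic carbon. Going by the values given here, no measured pair here shows such a change, and the fluoro of compound 2 and the chloro of compound 3 give values within the scatter of each other. The step from compound 3 to compound 4 is expected to be small, no change at the digits printed from compound 3 to compound 4 (within the scatter), with no clear direction beyond the scatter. Compound 4 is therefore estimated at 3300 nM, with a range from 1500 nM to 7500 nM.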

Compound 4, half-maximal inhibitory concentration: 1500 nM
Compound 4: middle estimate off by 2.2-fold (0.34 log units), on the high side; the range from low to high includes it.
By their numbers in this assay, from the lowest: compounds 4, 1 and 3 (each within the scatter of the next, the first and the last beyond it).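

In this assay, ethoxy in place of chloro on the aromatic carbon para to a large group gives a 2.2-fold lower number from compound 3 to compound 4 (0.34 log units; beyond the scatter). This shows that the number can respond to a change at this position, although the step is modest and a single pair cannot show which feature of ethoxy matters. Compounds 3 and 4 each have one reading, but repeat readings in this series agree closely: the several entries of compound 2 in this assay, 3100 nM; 3090 nM (2 entries)

As far as these compounds go, whether a methoxy group, a longer propoxy chain or an amine here would shift the number further remains open. So does whether ethoxy would give a similar step on the core of compound 1.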